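The compounds below may be only part of what the source reports. "The series", "measured", "known", "first", "only" and "open" are said of these compounds alone.

Working notes on the series. Compound 1 `CCCCCNC(=O)n1c(-c2ccccc2)coc1=O` gives 25 nM in an assay on isolated protein for inhibition of acid ceramidase (Homo sapiens), read by LC-MS, with a stated time of 1 h; on this read-out higher numbers stand for weaker inhibition and lower numbers for stronger inhibition. Compound 2 `CC(C)CNC(=O)n1cc(-c2ccccc2)oc1=O` gives 1700 nM in this assay. Compound 3 `O=C(NCCCCc1ccccc1)n1cc(-c2ccc(Cl)cc2)oc1=O` gives 83 nM in this assay and stands second highest of the three numbers: compound 1 lies lower and compound 2 lies higher, both gaps beyond the usual scatter. Compound 4 `CN1CCC(c2cn(C(=O)NCCCCc3ccccc3)c(=O)o2)CC1` is not yet measured. It differs from compound 3 in one place: 1-methylpiperidin-4-yl in place of 4-chlorophenyl on an aromatic carbon. Among the measured compounds shown here, no step between measured compounds isolates such an exchange, so the expectation rests on the change itself: an aromatic group leaving and a six-membered non-aromatic ring with one hetero atom entering is expected to raise the number in this assay by a moderate step of a 6.0-fold higher number from compound 3 to compound 4 (0.78 log units; beyond the scatter). Compound 4 is estimated at 500 nM, with a range from 100 nM to 3000 nM.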

Compound 4, half-maximal inhibitory concentration: 1400 nM
Beside the measured number, compound 4's estimate is 2.8-fold (0.45 log units) below it; the range from low to high includes it.
By their numbers in this assay, from the lowest: compound 1; then compound 3; then compounds 4 and 2 (each within the scatter of the next).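

Placing 1-methylpiperidin-4-yl in place of 4-chlorophenyl on this aromatic carbon gives a 17-fold higher number from compound 3 to compound 4 (1.23 log units; beyond the scatter) in this assay, a large step and the only one that isolates this position. The two groups are six-membered rings with the same heavy-atom count, so ring size and heavy-atom count alone do not set the number here. Nothing at hand gives a cause for the step. From the compounds shown here alone, whether cyclohexyl or piperidin-4-yl lacking the methyl at this carbon would fall nearer compound 3 or compound 4 remains open, so the step cannot yet be divided between loss of the aromatic ring and entry of the ring nitrogen.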